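Swapping nitro for sulfamoyl on a hydrazone lead

The source may report more compounds than this note shows. Statements on the series, on what has been measured and on what is new or still open speak of the compounds shown alone.

Compound 1 `CC(=O)/C(=N\c1cccc(Cl)c1)NNc1ccccc1[N+](=O)[O-]` is the compound around which this account turns. For the measured compounds named here, in an assay on isolated protein for binding affinity to corticotropin-releasing factor receptor 1 (Homo sapiens) (on this read-out higher numbers stand for weaker inhibition and lower numbers for stronger inhibition), compound 1 gives 51 nM, and that is the only plain number among the values shown. Compound 2 `CC(=O)/C(=N\Nc1ccccc1)Nc1cccc(Cl)c1` gives 2720 nM; 2720 nM (2 entries) in this assay, recorded twice with the same result. Compound 3 `CC(=O)/C(=N\Nc1ccccc1C)Sc1cccc(Cl)c1` reaches only a limit of this assay, > 10000 nM, so no number is known for it; this is the case noted as the limit of > 10000 nM in this assay, at which 1 of the 3 values shown sits. Compound 1 therefore stands alone with a measured value and a clear margin to the other two.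

Compound 4 `CC(=O)/C(=N\c1cccc(Cl)c1)NNc1ccccc1S(N)(=O)=O` has not yet been measured. It differs from compound 1 by sulfamoyl in place of nitro on an aromatic carbon of a six-membered aromatic ring of carbon only, ortho to a large group. Going by the values given here, no measured pair shows this exchange, so its effect is open. The step from compound 1 to compound 4 is expected to be a modest loss, a 3.9-fold higher number from compound 1 to compound 4 (0.59 log units; beyond the scatter), somewhat beyond the scatter. Compound 4 is thus estimated at 200 nM, within a range from 50 nM to 800 nM.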

Compound 4, inhibition constant: > 10000 nM
Compound 4 was reported as a limit; the forecaster's own chance of this, stated with the estimate: 5%; at least 50-fold (1.69 log units) between middle value and limit.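

The exchange shows that this place on the aromatic ring, ortho to a large group, does not accept every replacement for nitro: sulfamoyl in place of nitro on an aromatic carbon gives an at least 190-fold higher number from compound 1 to compound 4 (2.29 log units; beyond the scatter). In this assay compound 4 gives > 10000 nM, which is a limit of the assay and not a number. Among the compounds shown, this single exchange is enough to carry the shared core from a measured value to that limit: the limit of > 10000 nM in this assay, at which 2 of the 4 values shown sit.

The compounds shown leave open whether the loss belongs to sulfamoyl as a whole or to its nitrogen, which a methylsulfonyl group at the same place would help to separate. They also leave open how a nitrile, a carboxylic acid or an amine would fare there in place of nitro.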